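Swapping tert-butyl for phenyl on the shared core

A few compounds are considered here, and "the series" means these few. Any claim that something is new, unique, unknown or untested is made for them only; others in the source may bear on it.

In a functional assay on IGROV-1 cells (Homo sapiens) for inhibition (a lower number here means a stronger inhibitor, a higher number a weaker inhibitor), compound 1 (`O=C(O)/C=C/c1ccc(-c2ccc(O)c(CC3CCCCC3)c2)cc1`) gives 2580 nM and compound 2 (`CC(C)(C)c1cc(-c2ccc(/C=C/C(=O)O)cc2)ccc1O`) gives 30000 nM as the higher of the two numbers, which makes it the weaker inhibitor here. Compound 3 (`O=C(O)/C=C/c1ccc(-c2ccc(O)c(-c3ccccc3)c2)cc1`) is still unmeasured. It carries phenyl in place of tert-butyl on an aromatic carbon, ortho to a hydroxy group (phenyl in place of tert-butyl on an aromatic carbon). Among the measured compounds shown here, the one measured step at this place is a 12-fold higher number from compound 1 to compound 2 (1.07 log units; beyond the scatter) with tert-butyl in place of cyclohexylmethyl, and it is large and beyond the scatter. The number in this assay therefore responds strongly to the group here. Like the cyclohexylmethyl of compound 1, phenyl holds a ring, so a sizeable move to a lower number is expected, though a single step is thin support. The expected step is a 4.3-fold lower number from compound 2 to compound 3 (0.63 log units; beyond the scatter) in this reading. For compound 3 the estimated value is 7000 nM with a range from 2000 nM to 25000 nM as its likely span.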

Compound 3, half-maximal inhibitory concentration: 19000 nM
Estimate against measurement, compound 3: 2.7-fold (0.43 log units) below; measured number inside the range.
By their numbers in this assay, from the lowest: compound 1; then compounds 3 and 2 (each within the scatter of the next).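

In this assay, replacing tert-butyl with phenyl gives a 1.6-fold lower number from compound 2 to compound 3 (0.20 log units; within the scatter), so at this place, ortho to a hydroxy group, the two groups cannot be told apart. Replacing cyclohexylmethyl with phenyl gives a 7.4-fold higher number from compound 1 to compound 3 (0.87 log units; beyond the scatter), which leaves compound 1 as the strongest inhibitor of the three and shows that holding a ring is not enough to match it, since compound 3 also holds one. No measurement shown here accounts for the advantage of cyclohexylmethyl.

Still open, on these data alone, is whether that advantage follows the methyl link of cyclohexylmethyl or its non-aromatic ring, and a benzyl group or a cyclohexyl group at this place would separate the two. A longer chain, such as cyclohexylethyl, would show whether extending the link helps further.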